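Methyl on the phenolic oxygen of a propargylamine indole

The compounds below may be only part of what the source reports. "The series", "measured", "known", "first", "only" and "open" are said of these compounds alone.

The measured compounds:
Compound 1, `C#CCN(Cc1ccccc1)Cc1cc2ccccc2n1C`, 60000 nM
Compound 2, `C#CCNCc1cc2cc(O)ccc2n1C`, 8900 nM

The two measured compounds were tested in an assay on isolated protein for inhibition of Amine oxidase [flavin-containing] B (Rattus norvegicus); a lower number here means a stronger inhibitor, a higher number a weaker inhibitor. Compound 1 gives 60000 nM, and compound 2 gives 8900 nM. Of these two numbers, compound 2 has the lower one, and its gap to compound 1 lies beyond the scatter of the method. The two structures differ in more than one place, so no single change can be tied to that gap; the numbers only show where each compound stands.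

The next compound is compound 3, `C#CCNCc1cc2cc(OC)ccc2n1C`. It differs from compound 2 in one place: methyl in place of hydrogen on an oxygen on an aromatic ring. Read one bond further out, the change is hydroxy to methoxy. Among the measured compounds shown here, no measured pair isolates this change, so the size of the step must be expected rather than read. The step from compound 2 to compound 3 is estimated as a modest move to a lower number, of a size that may well stay within the scatter, a 1.8-fold lower number from compound 2 to compound 3 (0.25 log units; within the scatter). Compound 3 is therefore expected to give about 5000 nM, in a range from 1500 nM to 15000 nM.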

Compound 3, inhibition constant: 4 nM
Compound 3: the middle estimate sits 1300-fold (3.10 log units) above what was measured; the measured number lies below the stated range.
By their numbers in this assay, from the lowest: compound 3; then compound 2; then compound 1.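

In this assay the change from hydroxy to methoxy gives a 2200-fold lower number from compound 2 to compound 3 (3.35 log units; beyond the scatter), a large step beyond the scatter, and it comes from a single methyl, one heavy atom, on an oxygen on an aromatic ring. The two earlier compounds differ in more than one place and could tie their gap to no single change, whereas this pair shows that the number responds very strongly to what sits on this oxygen. No measurement shown here accounts for the size of the step, so it stands as an observation without an explanation.

The compounds shown leave open whether this step belongs to the methyl alone or whether a longer chain on the same oxygen, such as ethoxy, would give a similar number, and what an amine or a fluorine in place of the methoxy would give. They also leave open whether the same change from hydroxy to methoxy would give a step of this size in a compound that carries a benzyl group on its nitrogen, as compound 1 does.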